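The compounds below may be only part of what the source reports. "The series", "measured", "known", "first", "only" and "open" are said of these compounds alone.

Going by the values given here, compound 1 `N#Cc1cccc(C(=O)NCN2CCC(c3cccc[n+]3[O-])CC2)c1` gives 69% in a functional assay on HEK293 cells for agonist activity at D(4) dopamine receptor (Homo sapiens), read by FLIPR (on this read-out higher numbers stand for larger maximal responses and lower numbers for smaller maximal responses), the second highest of the three numbers so far. Compound 2 `O=C(CN1CCC(c2cccc[n+]2[O-])CC1)Nc1cccc(C(F)(F)F)c1` gives 75% in this assay, within the scatter of compound 1. Compound 3 `CCOc1cccc(C(=O)NCN2CCC(c3cccc[n+]3[O-])CC2)c1` gives 54% in this assay; the step of a number 15 percentage points lower from compound 1 to compound 3 (beyond the scatter) shows that exchanging the substituent on the aromatic ring already costs some efficacy. Compound 4 `O=C(NCN1CCC(c2cccc[n+]2[O-])CC1)c1ccccn1` has not yet been measured. It differs from compound 1 by pyridin-2-yl in place of 3-cyanophenyl on a carbonyl carbon. Among the compounds with values here, no measured step exchanges the whole aryl group on the carbonyl carbon, so the only bearing comes from compound 3, a modest loss. A modest fall, or none beyond the scatter, is therefore expected: a number 9 percentage points lower from compound 1 to compound 4 (within the scatter). For compound 4 the estimate is 60%, between 42% and 78%.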

Compound 4, largest response reached (reported as efficacy), in percent of the reference or control that the assay uses: 40%
For compound 4 the middle estimate is 20 percentage points above the measured one; measured number outside the range, below it.
By their numbers in this assay, from the lowest: compound 4; then compound 3; then compounds 1 and 2 (each within the scatter of the next).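

The step of a number 29 percentage points lower from compound 1 to compound 4 (beyond the scatter) shows that in this assay the aryl group on the carbonyl carbon itself matters, not only a substituent on it. Compound 3 at 54% and compound 4 at 40% both stand below compound 1, so neither replacement has kept the efficacy of the 3-cyanophenyl compound. No measurement at hand accounts for this loss.

Still open, going by these compounds, is whether the fall follows the ring nitrogen or the absence of the nitrile. A plain phenyl group or pyridin-3-yl on the same carbonyl carbon would help separate the two.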